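A few compounds are considered here, and "the series" means these few. Any claim that something is new, unique, unknown or untested is made for them only; others in the source may bear on it.

Measured compounds:
compound 1 `C=CCn1c(=O)/c(=C\c2cc(Br)ccc2F)[nH]c(=O)/c1=C\c1ccccc1OC`: 12900 nM
compound 2 `C=CCn1c(=O)/c(=C\c2ccc(Cl)c(Cl)c2)[nH]c(=O)/c1=C\c1ccccc1`: "not active" (no number reported)

Among the compounds with values here, in a functional assay on MOLT-4 cells (Homo sapiens) for cytotoxicity, read by CCK-8 assay, with a stated time of 72 h (on this read-out lower numbers stand for stronger inhibition and higher numbers for weaker inhibition), compound 1 gives 12900 nM, the only number among the measured compounds. Compound 2 is reported as "not active" (no number reported), with no number given. Compound 3 `C=CCn1c(=O)/c(=C\c2cccc(C)c2)[nH]c(=O)/c1=C\c1ccccc1OC` has not been measured; it differs from compound 1 by 3-methylphenyl in place of 5-bromo-2-fluorophenyl on a double-bonded chain carbon bound to an aromatic carbon. Within the data shown here, since no step between two measured compounds is available, the size of this change is uncertain, and a small move toward weaker inhibition, or none beyond the scatter, is expected. Compound 3 is estimated at 20000 nM, expected between 6000 nM and 60000 nM. The estimated step of a 1.6-fold higher number from compound 1 to compound 3 (0.19 log units; within the scatter) is modest.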

Compound 3, half-maximal inhibitory concentration: 16000 nM
Beside the measured number, compound 3's estimate is 1.3-fold (0.10 log units) above it; the range from low to high includes it.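

In this assay there is a 1.2-fold higher number from compound 1 to compound 3 (0.09 log units; within the scatter) when 3-methylphenyl takes the place of 5-bromo-2-fluorophenyl on a double-bonded chain carbon bound to an aromatic carbon. Within the data shown here, this is the first readable step at this position, and it shows that on this core, the two aromatic groups cannot be told apart within the scatter. Nothing measured here gives a reason for this result. Still open, going by these compounds, is whether an amine or a carboxylic acid on the aromatic ring at this position would shift the number beyond the scatter.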